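A few compounds are considered here, and "the series" means these few. Any claim that something is new, unique, unknown or untested is made for them only; others in the source may bear on it.

Working notes on the series built on the shared core. Compound 1 `CC1CCN(C2CCN(S(=O)(=O)c3cccnc3Cl)CC2)CC1` has been run in an ADME assay on HCT-116 cells (Homo sapiens) for cytotoxicity, read by CellTiter-Glo, with a stated time of 72 h; on this read-out higher numbers stand for weaker inhibition and lower numbers for stronger inhibition; in this assay compound 1 gives only a limit, > 10000 nM. Compound 2 `CC1CCN(C2CCN(S(=O)(=O)c3cnc(Cl)s3)CC2)CC1` in this assay likewise gives a limit, > 10000 nM. Compound 3 `CC1CCN(C2CCN(S(=O)(=O)c3ccc(Cl)c(Cl)c3)CC2)CC1` in this assay gives a limit as well, > 5000 nM. Compound 3 therefore stands where the whole set stands: at a limit and not at a number, the two readings being the limit of > 10000 nM in this assay, at which 2 of the 3 values shown sit, and (the limit of > 5000 nM in this assay, at which 1 of the 3 values shown sits).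

The next member is compound 4 `CC1CCN(C2CCN(S(=O)(=O)c3ccc(Cl)cc3Cl)CC2)CC1`. It differs from compound 3 by 2,4-dichlorophenyl in place of 3,4-dichlorophenyl on a sulfonyl sulfur. Among the compounds with values here, no measured step carries this same exchange. The steps that touch the group on the sulfonyl sulfur are a step that the two limits leave unreadable from compound 1 to compound 2, a step that the two limits leave unreadable from compound 1 to compound 3 and a step that the two limits leave unreadable from compound 2 to compound 3; none of them has a readable size, and none gives a direction. With three limits and no number in hand, no step beyond the scatter is expected in this assay in either direction, and the most likely outcome for compound 4 is again a limit.

Compound 4 is expected in this assay near 15000 nM, within 5000 nM to 50000 nM. The expected step is a step that the limit leaves unreadable from compound 3 to compound 4, which is taken to lie within the scatter.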

Compound 4, half-maximal inhibitory concentration: > 5000 nM
Compound 4: no number, only a limit (the forecaster's own chance of this, stated with the estimate: 85%); the middle value lies beyond the limit too.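

In this assay compound 4 gives > 5000 nM, a limit and not a number. Compound 1, compound 2 and compound 3 also give only limits, so no step among these four compounds can be read. The compounds shown leave open whether any exchange of the group on the sulfonyl sulfur changes the read-out, and in which direction.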